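A few compounds are considered here, and "the series" means these few. Any claim that something is new, unique, unknown or untested is made for them only; others in the source may bear on it.

Measured compounds in an assay on Sf9 cells for inhibition of protein deacetylase HDAC6 (Homo sapiens), read by fluorescence, with a stated time of 40 min, tested at 100 nM; on this read-out higher numbers stand for more inhibition at the one concentration tested (going by the name of the read-out) and lower numbers for less inhibition:
compound 1 `Cc1ccc(-c2nc(CNc3ccc(C(=O)NO)cc3)n(-c3ccccc3)n2)o1` gives 60.7%
compound 2 `COc1ccc(-c2nc(CNc3ccc(C(=O)NO)cc3)n(-c3ccccc3)n2)cc1` gives 77.6%
compound 3 `O=C(NO)c1ccc(NCc2nc(-c3ccc(Br)cc3)nn2-c2ccccc2)cc1` gives 54.7%

Compound 3 stands lowest of the three in this assay; the gap to compound 1 is within the scatter, the gap to compound 2 beyond it. The next compound, compound 4 `O=C(NO)c1ccc(NCc2nc(-c3ccccn3)nn2-c2ccccc2)cc1`, differs from compound 3 by pyridin-2-yl in place of 4-bromophenyl on an aromatic carbon: a 4-bromophenyl leaves and a pyridin-2-yl enters. Among the measured compounds shown here, the steps that bear on this are a number 6 percentage points lower from compound 1 to compound 3 (within the scatter) and a number 22.9 percentage points lower from compound 2 to compound 3 (beyond the scatter), both swaps of the same group on that ring carbon. For the measured compounds named here, no measured step covers a pyridin-2-yl here, so the expectation for compound 4 in this assay is a small rise at most, a number 5.3 percentage points higher from compound 3 to compound 4 (within the scatter), within the scatter. Compound 4 is estimated at 60%, range 40% to 80%.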

Compound 4, a percentage reported as inhibition, at one concentration (the size of the read-out at that concentration, not a potency): 58.6%
The estimate for compound 4 lay 1.4 percentage points above the measured number; the range from low to high includes it.
By their numbers in this assay, from the lowest: compounds 3, 4 and 1 (each within the scatter of the next); then compound 2.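

In this assay, among the compounds shown here, pyridin-2-yl, the first group here with a ring hetero atom of nitrogen and a hydrogen-bond acceptor in a six-membered ring at this carbon, gives a number 3.9 percentage points higher from compound 3 to compound 4 (within the scatter) and a number 2.1 percentage points lower from compound 1 to compound 4 (within the scatter) with no separation from either group. Against 4-methoxyphenyl it gives a number 19 percentage points lower from compound 2 to compound 4 (beyond the scatter), so compound 2 remains the only one apart from the others at this position. Nothing measured accounts for these steps.

Open, going by these compounds, is whether pyridin-3-yl would match pyridin-2-yl here. Also open, on these data alone, is whether a 4-aminophenyl or 4-carboxyphenyl group would stand with compound 2 or with the other three.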